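Kinase inhibitor series: amine substituent on the shared core

The source may hold more compounds than are shown below. What is called first, only, known or untested is meant among the compounds shown, and "the series" means these compounds.

Measured compounds:
compound 1 `N#Cc1cnc(NCc2cnccc2C(F)(F)F)cc1NC[C@H]1C[C@@H](O)C1` — 300 nM
compound 2 `CO[C@H]1CC[C@H](Nc2cc(NCc3cnccc3C(F)(F)F)ncc2C#N)CC1` — 1100 nM

Working notes. In an assay on isolated protein for inhibition of protein kinase C theta type (Homo sapiens), read by TR-FRET, with a stated time of 2 h (a lower number here means a stronger inhibitor, a higher number a weaker inhibitor), compound 1 gives 300 nM. For the measured compounds named here, compound 2 carries 4-methoxycyclohexyl where compound 1 has (3-hydroxycyclobutyl)methyl, and the step of a 3.7-fold higher number from compound 1 to compound 2 (0.56 log units; beyond the scatter) puts compound 2 at the highest number of the two measured, with compound 1 as its only neighbour.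

Compound 3 `N#Cc1cnc(NCc2cnccc2C(F)(F)F)cc1NC[C@H]1CC[C@H](O)CC1` is not yet measured in this assay. It differs from compound 2 by (4-hydroxycyclohexyl)methyl in place of 4-methoxycyclohexyl on a nitrogen on an aromatic ring. Going by the values given here, the entering (4-hydroxycyclohexyl)methyl resembles the (3-hydroxycyclobutyl)methyl of compound 1 more closely than the 4-methoxycyclohexyl of compound 2 does, so the only step that bears on it is the one from compound 1 to compound 2, and it is read here in reverse: a modest move to a lower number. The expected step is a 2.4-fold lower number from compound 2 to compound 3 (0.39 log units; beyond the scatter), a lower number than compound 2, though the ring size is larger than in compound 1 and the data hold nothing on that point. Compound 3 is expected to give 450 nM in this assay, within a range of 150 nM to 1300 nM.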

Compound 3, half-maximal inhibitory concentration: 50 nM
Compound 3: middle estimate off by 9.0-fold (0.95 log units), on the high side; measured number below the stated range.
By their numbers in this assay, from the lowest: compound 3; then compound 1; then compound 2.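

In this assay this position proves far more sensitive than the first pair showed: a 22-fold lower number from compound 2 to compound 3 (1.34 log units; beyond the scatter) comes from exchanging 4-methoxycyclohexyl for (4-hydroxycyclohexyl)methyl, two groups with the same atoms joined differently, and this step is much larger than the one that separated the first two compounds. For the compounds shown here, the ring also matters, which the earlier compounds could not show: with the hydroxyl and the methylene link both kept, 4-hydroxycyclohexyl in place of 3-hydroxycyclobutyl gives a 6.0-fold lower number from compound 1 to compound 3 (0.78 log units; beyond the scatter) so a larger carbon ring is not penalised in this pair, and compound 3 now holds the lowest number of the three. No measurement on hand accounts for either step.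

The step from compound 2 bundles two changes, methoxy to hydroxyl and the added methylene link, and the shown compounds cannot divide it, since neither (4-methoxycyclohexyl)methyl nor 4-hydroxycyclohexyl set directly on the nitrogen appears among them. Also open, going by these compounds, is whether an amine or a carboxylic acid in place of the hydroxyl on the cyclohexane ring would keep the number of compound 3, and whether the other stereoisomer of the (4-hydroxycyclohexyl)methyl group would do so.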